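A few compounds are considered here, and "the series" means these few. Any claim that something is new, unique, unknown or untested is made for them only; others in the source may bear on it.

Working notes on the series. Within the data shown here, in an assay on microsomes for inhibition of Amine oxidase [flavin-containing] B (Homo sapiens), read by fluorescence and spectrophotometry, with a stated time of 20 min (on this read-out lower numbers stand for stronger inhibition and higher numbers for weaker inhibition), compound 3 `O=c1ccoc2ccc(OCc3cccc(Cl)c3)cc12` gives 3.6 nM, the lowest number among the three compounds measured so far. Compound 1 `O=c1ccoc2ccc(OCCc3ccccc3)cc12` gives 21 nM, and compound 2 `O=c1ccoc2ccc(OCCCc3ccccc3)cc12` gives 57 nM; both numbers lie above that of compound 3, and the gap to compound 2 is the wider one. Among the measured compounds shown here, the single step recorded between measured compounds is a 2.7-fold higher number from compound 1 to compound 2 (0.43 log units; beyond the scatter), a change on the chain rather than on the ring.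

Compound 4 `O=c1ccoc2ccc(OCc3cccc(F)c3)cc12` differs from compound 3 by fluoro in place of chloro on an aromatic carbon. For the measured compounds named here, no measured step bears directly on an exchange of one halogen for another on the ring; the step from compound 1 to compound 2 concerns the chain only and gives no guidance here. With nothing in the series to suggest a large shift from so small a change, the expectation in this assay is a step that stays within or just beyond the scatter, with a slight lean toward a higher number. The expected step is a 1.9-fold higher number from compound 3 to compound 4 (0.29 log units; within the scatter). Compound 4 is accordingly estimated at 7 nM, with a range from 2.5 nM to 22 nM.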

Compound 4, half-maximal inhibitory concentration: 13 nM
Compound 4: middle estimate off by 1.9-fold (0.27 log units), on the low side; the range from low to high includes it.
By their numbers in this assay, from the lowest: compound 3; then compounds 4 and 1 (each within the scatter of the next); then compound 2.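

In this assay, the exchange of chloro for fluoro on an aromatic carbon, meta to a large group, is not a silent one: the series gives a 3.6-fold higher number from compound 3 to compound 4 (0.56 log units; beyond the scatter), so this place on the ring responds to a change of a single halogen atom, which the earlier step on the chain alone, a 2.7-fold higher number from compound 1 to compound 2 (0.43 log units; beyond the scatter), could not show. Of the two halogens, chloro goes with the lower number at this place; this rests on one pair only, and no wider order of substituents follows from it. Nothing measured on the series accounts for the size of this step.

The compounds shown leave open how bromo, methoxy, nitrile or a plain hydrogen at this same place would compare with chloro and fluoro, and so whether the number follows any regular trend across substituents there. Also open, on these data alone, is whether the exchange of chloro for fluoro gives a step of similar size at another carbon of the ring or on a compound with a longer chain, such as the chain of compound 2.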